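Cyclopropyl in Place of Methylethenyl on the Amide Carbonyl

The source may report more compounds than this note shows. Statements on the series, on what has been measured and on what is new or still open speak of the compounds shown alone.

Compound 1 `COc1ccc(CNc2cc(OC)c(OC)c(OC)c2)cc1Br`: 39800 nM
Compound 2 `C=C(C)C(=O)N(Cc1ccc(OC)c(O)c1)c1cc(OC)c(OC)c(OC)c1`: 200 nM
Compound 3 `COc1cc(NCc2ccc(C)cc2)cc(OC)c1OC`: > 80000 nM

In a functional assay on KYSE-450 cells (Homo sapiens) for inhibition, read by MTT assay, with a stated time of 48 h (a higher number here means a weaker inhibitor, a lower number a stronger inhibitor), compound 2 gives 200 nM, the lowest of the two numbers shown. Compound 1 gives 39800 nM, a far higher number, well beyond the scatter. For compound 3 the value > 80000 nM is a limit of the assay, not a number, so no comparison to it is made (the limit of > 80000 nM in this assay, at which 1 of the 3 values shown sits).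

Compound 4 `COc1ccc(CN(C(=O)C2CC2)c2cc(OC)c(OC)c(OC)c2)cc1O` keeps everything in compound 2 except one group on the carbonyl carbon:

cyclopropyl in place of 1-methylethenyl on a carbonyl carbon

For the measured compounds named here, no measured pair shows this change, so any expectation rests on compound 2 alone. The step of a 13-fold higher number from compound 2 to compound 4 (1.10 log units; beyond the scatter) is expected to go toward a higher number, beyond the scatter. Compound 4 is therefore estimated at 2500 nM, within 400 nM to 20000 nM.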

Compound 4, half-maximal inhibitory concentration: 80 nM
The estimate for compound 4 lay 31-fold (1.49 log units) above the measured number; the measured number lies below the stated range.
By their numbers in this assay, from the lowest: compound 4; then compound 2; then compound 1. At a limit, above all of these: compound 3.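

Cyclopropyl in place of 1-methylethenyl on the carbonyl carbon gives a 2.5-fold lower number from compound 2 to compound 4 (0.40 log units; beyond the scatter) in this assay and so the double bond of compound 2 is not needed at this position for activity. A saturated ring with the same count of carbons serves at least as well here, and the position accepts a change of shape without a loss. Nothing measured here says why the ring gives the lower number.

Going by these compounds, whether a cyclobutyl ring or a longer chain on the carbonyl carbon would lower the number further stays open. So does the effect of an amine at this position.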